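The source may report more compounds than this note shows. Statements on the series, on what has been measured and on what is new or still open speak of the compounds shown alone.

Working notes on the series sharing one core. In a functional assay on BXPC-3 cells (Homo sapiens) for cytotoxicity, read by MTT assay, with a stated time of 72 h (on this read-out higher numbers stand for weaker inhibition and lower numbers for stronger inhibition), compound 1 `COc1ccc(-c2ccc(NC3=CC(=O)c4ncncc4C3=O)cc2)cc1` gives 3500 nM. Compound 2 `CC(=O)c1cccc(NC2=CC(=O)c3ncncc3C2=O)c1` gives 5200 nM in this assay; the two numbers lie within the scatter of each other, so nothing separates compound 1 from compound 2, although of the two numbers reported compound 1 carries the lower one. Compound 3 `O=C1C(Nc2cccc(B(O)O)c2)=CC(=O)c2ncncc21` in this assay reaches only the limit > 10000 nM and no number. Among the compounds with values here, the single one-place step on record, an at least 1.9-fold higher number from compound 2 to compound 3 (0.28 log units; that floor lies within the scatter), exchanges one group of 3 heavy atoms for another on an aromatic carbon and rests on (the limit of > 10000 nM in this assay, at which 1 of the 3 values shown sits), so its size is a floor rather than a measurement.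

Compound 4 `Nc1ccc(-c2ccc(NC3=CC(=O)c4ncncc4C3=O)cc2)cc1` has not been measured. It differs from compound 1 by amino in place of methoxy on an aromatic carbon. Within the data shown here, no measured step touches that exchange: the one step on record concerns a different group in a different compound and does not even clear the scatter. The expectation for this assay is therefore no step beyond the scatter, in either direction. Compound 4 is expected to give an estimate of 3200 nM, with a range of 1100 nM to 9500 nM. The step this estimate means, a 1.1-fold lower number from compound 1 to compound 4 (0.04 log units; within the scatter), is expected to sit within the scatter.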

Compound 4, half-maximal inhibitory concentration: 3500 nM
For compound 4 the middle estimate is 1.1-fold (0.04 log units) below the measured one, within the range that was stated.
By their numbers in this assay, from the lowest: compounds 1, 4 and 2 (each within the scatter of the next). At a limit, above all of these: compound 3.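

Amino in place of methoxy, on an aromatic carbon para to a large group, gives no change at the digits printed from compound 1 to compound 4 (within the scatter) in this assay, and this pair is the only reading of this position and this exchange, since compounds 2 and 3 carry neither group. Going from 4-methoxyphenyl to 4-aminophenyl, a group with 0 hydrogen-bond donors gives way to one with 1 hydrogen-bond donor, and in this one pair the number does not respond to that difference. Nothing on record bears on why the number stays where it is.

Open, from the compounds shown here alone, is whether other groups at this place, such as a carboxylic acid, a dimethylamino group or a longer alkoxy chain, would stay within the scatter of compound 1 or move beyond it. Also open, going by these compounds, is whether amino in place of methoxy reads the same way in another compound of the series, as a single pair in this assay settles this exchange for compound 1 alone.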